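The source may hold more compounds than are shown below. What is called first, only, known or untested is meant among the compounds shown, and "the series" means these compounds.

Compound 1, `O=C(Cc1cccnc1)c1cc2cc(F)ccc2[nH]1`, gives 24% in an in vitro assay on P815B cells for inhibition of Indoleamine 2,3-dioxygenase 1 (Mus musculus), tested at 20 uM; a higher number here means more inhibition at the concentration tested (going by the name of the read-out), a lower number less inhibition.
Compound 2, `O=C(Cc1cccnc1)c1cc2c(F)cccc2[nH]1`, gives 12%.
Compound 3, `O=C(Cc1cccnc1)c1cc2ccccc2[nH]1`, gives 13%.

Compound 3 stands second highest of the three numbers. Its nearest neighbour is compound 2: the step of a number 1 percentage points higher from compound 2 to compound 3 (within the scatter) is within the scatter, so the two cannot be told apart. The furthest is compound 1: the step of a number 11 percentage points lower from compound 1 to compound 3 (beyond the scatter) is beyond the scatter, a modest loss when a fluoro on an aromatic carbon is swapped for hydrogen.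

Compound 4, `O=C(Cc1cccnc1)c1cc2cc(Br)ccc2[nH]1`, differs from compound 3 in one place: bromo in place of hydrogen on an aromatic carbon. Among the measured compounds shown here, the only measured step that bears on this change is a number 11 percentage points lower from compound 1 to compound 3 (beyond the scatter), where removing a halogen from the carbon-only six-membered ring of the core lowered the number modestly. Putting a halogen back in the form of bromo is therefore expected to move the number the other way, by a step of similar modest size rather than none at all. Compound 4 is expected to reach 23%, with a range from 8% to 38%, which means an estimated step of a number 10 percentage points higher from compound 3 to compound 4 (within the scatter).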

Compound 4, a percentage reported as inhibition, at one concentration (the size of the read-out at that concentration, not a potency): "not active" (no number reported)
Compound 4: no number reported, so the estimate cannot be set against anything.
By their numbers in this assay, from the lowest: compounds 2 and 3 (each within the scatter of the next); then compound 1.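

Among the compounds shown here, compound 4 is reported in this assay only as "not active", without a number, so no step linking it to compound 3 or compound 1 can be read. Nothing available bears on this result. From the compounds shown here alone, how bromo in place of hydrogen on this aromatic carbon shifts the number, and how bromo compares with fluoro there, stays open.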